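The compounds below may be only part of what the source reports. "The series", "measured", "known", "first", "only" and "open" are said of these compounds alone.

This piece follows one structural change on a shared core, judged by an in vitro ADME assay on microsomes from liver (Homo sapiens) for metabolic stability; on this read-out higher numbers stand for fast clearance and lower numbers for slow clearance. Compound 1 `Cc1oc(-c2ccccc2)nc1CN1CCCC(C(=O)NCC2CCOCC2)C1` gives 105 mL.min-1.g-1 in this assay. For the measured compounds named here, it sits level with compound 3 `Cc1cccc(CNC(=O)[C@@H]2C[C@@H](c3nc(C)no3)CN(Cc3nc(-c4ccccc4)oc3C)C2)n1`, which gives 105 mL.min-1.g-1; together these two stand at the low end of the three numbers measured so far. Compound 2 `COC[C@@H]1C[C@@H](C(=O)NCC2CCOCC2)CN(Cc2nc(-c3ccccc3)oc2C)C1` gives 239 mL.min-1.g-1, a higher number that lies beyond the usual scatter, while the gap between compound 1 and compound 3 does not.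

The step to be judged leads from compound 1 to compound 4 `Cc1cccc(CNC(=O)C2CCCN(Cc3nc(-c4ccccc4)oc3C)C2)n1`, which has not yet been measured in this assay. The change is 6-methylpyridin-2-yl in place of oxan-4-yl on a saturated chain carbon bound to an amide-type nitrogen. Going by the values given here, no measured pair shows exactly this change on its own. Compound 3, however, also carries a (6-methylpyridin-2-yl)methyl amide, though on a differently substituted core, and its value of 105 mL.min-1.g-1 sits level with compound 1. On that basis the step is expected to stay small: the estimated step of a 1.1-fold higher number from compound 1 to compound 4 (0.06 log units; within the scatter) is expected to lie within the usual scatter, with no clear direction either way. Compound 4 is therefore expected to give about 120 mL.min-1.g-1 in this assay, with a range from 60 mL.min-1.g-1 to 250 mL.min-1.g-1.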

Compound 4, intrinsic clearance in microsomes: 158 mL.min-1.g-1
The estimate for compound 4 lay 1.3-fold (0.12 log units) below the measured number; the measured number falls inside the stated range.
By their numbers in this assay, from the lowest: compounds 1, 3, 4 and 2 (each within the scatter of the next, the first and the last beyond it).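

For the compounds shown here, this pair gives the first direct reading of this change with the rest of compound 1 held fixed: 6-methylpyridin-2-yl in place of oxan-4-yl on a saturated chain carbon bound to an amide-type nitrogen gives a 1.5-fold higher number from compound 1 to compound 4 (0.18 log units; within the scatter) in this assay. At this place, then, a non-aromatic ring with one oxygen can be exchanged for an aromatic ring with one nitrogen and a methyl group, and the step stays inside the usual scatter of repeated measurements on this read-out. There is no measured information here that would explain the result or the size of the step.

One pair at one place leaves open how other groups would read here, for example plain pyridin-2-yl without its methyl group, an open carbon chain, or an amine in place of the ring. It also leaves open whether the same exchange would give a similar step on the more heavily substituted cores of compound 2 and compound 3.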